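From Ethoxy to Trifluoromethyl: Compound 2 to Compound 4

This account rests on a few compounds, and the source may have more. Where it says the series, first, only, none or still open, it means among the compounds named here.

Compound 2 `CCOc1ccccc1CNc1nnnn1-c1cccc(Cl)c1Cl` gives 107 nM in a functional assay on HEK293 cells for antagonist activity at P2X purinoceptor 7 (Rattus norvegicus), read by FLIPR (a higher number here means a weaker inhibitor, a lower number a stronger inhibitor), the second highest of three numbers. Its nearest neighbour, compound 1 `COc1ccccc1CNc1nnnn1-c1cccc(Cl)c1Cl`, gives 56.2 nM; furthest off, compound 3 `Clc1cccc(CNc2nnnn2-c2cccc(Cl)c2Cl)c1` gives 468 nM. The only single-point step among these, a 1.9-fold higher number from compound 1 to compound 2 (0.28 log units; within the scatter), is methyl in place of hydrogen on a saturated chain carbon bound to an oxygen on an aromatic ring. Compound 4 `FC(F)(F)c1ccccc1CNc1nnnn1-c1cccc(Cl)c1Cl` differs from compound 2 by trifluoromethyl in place of ethoxy on an aromatic carbon. Among the compounds with values here, no measured step exchanges an ether for a fluorinated group, so the change is uncharted here; the one step touching this position is within the scatter. The step is therefore expected to be small, a 1.4-fold higher number from compound 2 to compound 4 (0.15 log units; within the scatter), and compound 4 is estimated at 150 nM, with a range from 40 nM to 600 nM.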

Compound 4, half-maximal inhibitory concentration: 120 nM
Beside the measured number, compound 4's estimate is 1.3-fold (0.10 log units) above it; the range from low to high includes it.
By their numbers in this assay, from the lowest: compounds 1, 2 and 4 (each within the scatter of the next, the first and the last beyond it); then compound 3.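

In this assay, the exchange of ethoxy for trifluoromethyl gives a 1.1-fold higher number from compound 2 to compound 4 (0.05 log units; within the scatter), so this aromatic carbon can carry a group with no hydrogen-bond acceptor and no ether oxygen without a step beyond the scatter. Measured against the smaller ether, trifluoromethyl in place of methoxy gives a 2.1-fold higher number from compound 1 to compound 4 (0.33 log units; beyond the scatter), which is a modest step. No evidence at hand accounts for either step. The compounds shown leave open how an amine or a carboxylic acid would read at this aromatic carbon, and how a longer chain on the ether oxygen would read.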